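The compounds below may be only part of what the source reports. "The series", "measured", "known", "first", "only" and "open" are said of these compounds alone.

Three acylguanidines of a shared core have been measured in a functional assay on cardiac atrium for antagonist activity at histamine H2 receptor (Cavia porcellus); on this read-out higher numbers stand for weaker binding and lower numbers for tighter binding. Compound 1 `N/C(=N\C(=O)CCc1c[nH]c2ccccc12)NCCCc1c[nH]cn1` gives 437 nM. Compound 2 `CCC(=O)/N=C(\N)NCCCc1c[nH]cn1` gives 347 nM, and compound 3 `CC(=O)/N=C(\N)NCCCc1c[nH]cn1` gives 363 nM. Compound 3 thus stands second highest of the three numbers, yet its nearest neighbour is compound 2, and its furthest is compound 1, both within the scatter of it, so no order among the three can be read from these values.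

Compound 4 `CC(C)C(=O)/N=C(\N)NCCCc1c[nH]cn1` differs from compound 3 in one place: isopropyl in place of methyl on a carbonyl carbon. Going by the values given here, the one measured step that bears on this change is a 1.0-fold higher number from compound 2 to compound 3 (0.02 log units; within the scatter), which shows that lengthening the chain on that carbonyl carbon by one carbon left this assay unmoved. Adding two carbons as a branch in the same place is therefore expected to move the number little, if at all, beyond the scatter, with no direction favoured. Compound 4 is estimated at 380 nM, with a range from 150 nM to 950 nM, which corresponds to an expected step of a 1.0-fold higher number from compound 3 to compound 4 (0.02 log units; within the scatter).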

Compound 4, dissociation constant: 302 nM
Estimate against measurement, compound 4: 1.3-fold (0.10 log units) above; low and high end bracket the measured number.
By their numbers in this assay, from the lowest: compounds 4, 2, 3 and 1 (each within the scatter of the next).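

In this assay, isopropyl in place of methyl on a carbonyl carbon gives a 1.2-fold lower number from compound 3 to compound 4 (0.08 log units; within the scatter), so this position accepts a branched group with three carbons, which compound 2 and compound 3 could not show. The second step isolates the branch itself: methyl in place of hydrogen on a saturated chain carbon bound to a carbonyl carbon and a saturated chain carbon gives a 1.1-fold lower number from compound 2 to compound 4 (0.06 log units; within the scatter), so branching at that carbon also stays within the scatter. No evidence is at hand on why these steps are so small. Apart from the chain of compound 1, the groups shown on this carbonyl carbon hold only carbon and hydrogen, so it stays open whether an amine or a carboxylic acid there would move the number beyond the scatter. No step shown here goes beyond the scatter, so what this position can gain or lose remains unknown.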